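A few compounds are considered here, and "the series" means these few. Any claim that something is new, unique, unknown or untested is made for them only; others in the source may bear on it.

Compound 1 `CC1(C)[C@H]2CC[C@]1(C)N(Cc1cn(-c3ccc(C#N)cc3)nn1)C(=O)C2` gives 90 nM in a functional assay on LoVo cells (Homo sapiens) for inhibition, read by MTT assay, with a stated time of 24 h; on this read-out lower numbers stand for stronger inhibition and higher numbers for weaker inhibition. Among the three measured compounds it stands second highest. Its nearest neighbour is compound 3 `CC1(C)[C@H]2CC[C@]1(C)N(Cc1cn(-c3ccccc3Cl)nn1)C(=O)C2`, which gives 190 nM; the change between them, 2-chlorophenyl in place of 4-cyanophenyl on an aromatic nitrogen, produces a 2.1-fold higher number from compound 1 to compound 3 (0.32 log units; beyond the scatter). Furthest from it lies compound 2 `CC1(C)[C@H]2CC[C@]1(C)N(Cc1cn(-c3ccccc3F)nn1)C(=O)C2`, which gives 40 nM; that change, 2-fluorophenyl in place of 4-cyanophenyl on an aromatic nitrogen, produces a 2.3-fold lower number from compound 1 to compound 2 (0.35 log units; beyond the scatter). Between compounds 2 and 3, chloro in place of fluoro on an aromatic carbon gives a 4.8-fold higher number from compound 2 to compound 3 (0.68 log units; beyond the scatter).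

Compound 4 `COc1ccc(-n2cc(CN3C(=O)C[C@@H]4CC[C@@]3(C)C4(C)C)nn2)cc1` differs from compound 1 by methoxy in place of cyano on an aromatic carbon. Going by the values given here, none of the measured steps alters the group para to a large group while keeping it in that place; the two steps from compound 1 both move the substituent to another position of the ring as well as changing its identity, and both were modest. The swap between compounds 2 and 3 concerns halogens only and bears little on a methoxy in place of a cyano. The evidence therefore supports expecting a modest step at most, in no clear direction. Compound 4 is estimated at 110 nM, expected to fall between 40 nM and 320 nM. That estimate corresponds to an expected step of a 1.2-fold higher number from compound 1 to compound 4 (0.09 log units; within the scatter).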

Compound 4, half-maximal inhibitory concentration: 70 nM
The estimate for compound 4 lay 1.6-fold (0.20 log units) above the measured number; low and high end bracket the measured number.
By their numbers in this assay, from the lowest: compounds 2, 4 and 1 (each within the scatter of the next, the first and the last beyond it); then compound 3.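

Cyano and methoxy have the same count of heavy atoms and of hydrogen-bond acceptors, and this is the first step that changes the group while keeping it para to a large group: a 1.3-fold lower number from compound 1 to compound 4 (0.11 log units; within the scatter) shows that, in this assay, 4-cyanophenyl and 4-methoxyphenyl cannot be told apart. The ring changes that also shift the substituent separate the halogen compounds more clearly, with a 2.7-fold lower number from compound 3 to compound 4 (0.43 log units; beyond the scatter) setting 4-methoxyphenyl apart from 2-chlorophenyl, whereas a 1.8-fold higher number from compound 2 to compound 4 (0.24 log units; within the scatter) leaves it indistinguishable from 2-fluorophenyl, so the para-substituted compounds 1 and 4 do not share the gap seen between the two halogen compounds. Nothing in the data shown accounts for any of these numbers.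

From the compounds shown here alone, whether the same place would accept an amine, a carboxylic acid or a longer chain with as little effect as methoxy and cyano remains open. Also open, going by these compounds, is whether cyano or methoxy would give similar numbers on the ring carbon that bears fluoro or chloro in compounds 2 and 3, which would separate the effect of the group from that of its place.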